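This account rests on a few compounds, and the source may have more. Where it says the series, first, only, none or still open, it means among the compounds named here.

For the measured compounds named here, in a functional assay on MCF7 cells (Homo sapiens) for inhibition, in the absence of a further agent (on this read-out higher numbers stand for weaker inhibition and lower numbers for stronger inhibition), compound 1 (`Nc1ccc(-c2cc(=O)c3c(N)c(F)cc(F)c3o2)cc1F`) gives 1.2 nM as its only single number, and one further entry for it carries no single number. Compound 2 (`COc1ccc(N)c2c(=O)cc(-c3ccc(N)cc3)oc12`) gives 21000 nM; 19000 nM (2 entries) in the same test, with its entries reading the several entries of compound 2 in this assay, 21000 nM; 19000 nM (2 entries) here, so the value of compound 1 lies far lower. Compound 3 (`Nc1c(F)cc(-c2cc(=O)c3c(N)c(F)cc(F)c3o2)cc1F`) is still unmeasured. Its change from compound 1 is fluoro in place of hydrogen on an aromatic carbon. Going by the values given here, no measured step covers this change, so only a modest weakening is expected in this assay, and the estimated move is a 3.3-fold higher number from compound 1 to compound 3 (0.52 log units; beyond the scatter) in size. For compound 3 the estimate is 4 nM, within an expected range from 0.5 nM to 40 nM at this stage.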

Compound 3, half-maximal inhibitory concentration: 4 nM
Compound 3: middle estimate and measured number agree at the digits printed; low and high end bracket the measured number.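

In this assay, placing a fluoro group on the aromatic carbon ortho to an amino group gives a 3.3-fold higher number from compound 1 to compound 3 (0.52 log units; beyond the scatter). This step is modest but beyond the usual scatter, so this position does respond to the change, and inhibition stays strong with fluoro there. Nothing shown here explains this shift. Fluoro is the only replacement for hydrogen seen at this position, so the compounds shown leave open how a chlorine, a methoxy group or a hydroxyl group would compare.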